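Methyl in place of hydroxy on a bis-arylidene ketone

The source may report more compounds than this note shows. Statements on the series, on what has been measured and on what is new or still open speak of the compounds shown alone.

The study measures compounds for their effect in an assay on isolated protein for inhibition of Alpha glucosidase (Homo sapiens), with stated times of 5 min and 15 min, tested at 50 uM; a higher number here means more inhibition at the concentration tested (going by the name of the read-out), a lower number less inhibition. For the measured compounds named here, compound 1 `O=C1/C(=C/c2ccccc2)CCC/C1=C\c1ccc(O)cc1` is the first of two measured compounds; in this assay compound 1 gives 53%. The second, compound 2 `O=C(/C=C(O)/C=C/c1ccc(O)cc1)c1cc(Cl)ccc1O`, carries a different core; in this assay compound 2 gives 45.3%. The two numbers lie within the usual scatter of each other, so compound 1 does not stand apart from compound 2 on the numbers shown. Going by the values given here, no step between compounds that differ in one place has been measured yet.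

Compound 3 `Cc1ccc(/C=C2\CCC/C(=C\c3ccccc3)C2=O)cc1` has not been measured. It differs from compound 1 in one place: methyl in place of hydroxy on an aromatic carbon. Among the compounds with values here, with no comparable step measured, the change is expected to cost a modest amount of inhibition, around the size of the scatter, so the expected step is a number 13 percentage points lower from compound 1 to compound 3 (beyond the scatter). Compound 3 is therefore estimated at 40%, with a range from 20% to 60%.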

Compound 3, a percentage reported as inhibition, at one concentration (the size of the read-out at that concentration, not a potency): 34.1%
Estimate against measurement, compound 3: 5.9 percentage points above; the measured number falls inside the stated range.
By their numbers in this assay, from the lowest: compound 3; then compounds 2 and 1 (each within the scatter of the next).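

Replacing 4-hydroxyphenyl with 4-methylphenyl gives the first step measured at a single place on the core of compound 1, and in this assay it is beyond the scatter (a number 18.9 percentage points lower from compound 1 to compound 3 (beyond the scatter)). The earlier compounds shown here could not show this, since their different cores left no group to compare at this position; here, inhibition does change with the group on that aromatic carbon. Nothing shown gives a reason for the step.

A single replacement cannot separate the loss of a hydrogen-bond donor from the loss of a hydrogen-bond acceptor, since hydroxy is counted as both and methyl as neither. Going by these compounds, whether an amine or a methoxy group at the same place would keep the inhibition of compound 1 or follow compound 3 remains open.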